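Adding propylsulfanyl to the aromatic part of compound 2

A few compounds are considered here, and "the series" means these few. Any claim that something is new, unique, unknown or untested is made for them only; others in the source may bear on it.

- compound 1 `C=CCOC(=O)C1=C2C(=NC1=O)c1cccc3cccc2c13`: 4800 nM
- compound 2 `CCCSC(=O)COC(=O)C1=C2C(=NC1=O)c1cccc3cccc2c13`: 10100 nM

In a functional assay on BXPC-3 cells (Homo sapiens) for antiproliferative activity, read by sulforhodamine B assay, with a stated time of 72 h (a lower number here means a stronger inhibitor, a higher number a weaker inhibitor), compound 2 gives the higher number of the pair, at 10100 nM. Compound 3 `CCCSC(=O)COC(=O)C1=C2C(=NC1=O)c1cccc3c(SCCC)ccc2c13` carries propylsulfanyl in place of hydrogen on an aromatic carbon. For the measured compounds named here, the only measured step, a 2.1-fold higher number from compound 1 to compound 2 (0.32 log units; beyond the scatter), is modest and changes a different part of the molecule, so it offers only a rough scale. Going by the values given here, no measured step bears on this place, so no step beyond the scatter is expected, though either direction remains open. The expected change is a 1.4-fold lower number from compound 2 to compound 3 (0.16 log units; within the scatter). For compound 3 the estimated value is 7000 nM, with an expected range of 2000 nM to 22000 nM.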

Compound 3, half-maximal inhibitory concentration: 56300 nM
For compound 3 the middle estimate is 8.0-fold (0.91 log units) below the measured one; measured number outside the range, above it.
By their numbers in this assay, from the lowest: compound 1; then compound 2; then compound 3.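

In this assay, for the compounds shown here, propylsulfanyl in place of hydrogen on an aromatic carbon gives a 5.6-fold higher number from compound 2 to compound 3 (0.75 log units; beyond the scatter), the first reading at this place, and the change weakens the compound. The earlier step concerned the saturated chain, whereas this one shows that the aromatic carbon of the shared core also responds to substitution. No available evidence accounts for the shift. Whether the loss is specific to propylsulfanyl or follows from any substituent on this carbon remains open, since only one group is shown there. A methoxy group or an amine on the same aromatic carbon would help separate these possibilities.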